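The source may hold more compounds than are shown below. What is called first, only, known or untested is meant among the compounds shown, and "the series" means these compounds.

For the measured compounds named here, in a functional assay on HepG2 cells (Homo sapiens), read by MTT assay, with a stated time of 48 h (a higher number here means a weaker inhibitor, a lower number a stronger inhibitor), three compounds sharing one core have numbers so far. Compound 1 `CCN(CC)CCNC(=O)c1ccc(C(CC)(CC)c2ccc(OCC(=O)C(C)(C)C)c(C)c2)n1CC` gives 620 nM and compound 3 `CCn1c(C(=O)NCCCN(C)C)ccc1C(CC)(CC)c1ccc(OCC(=O)C(C)(C)C)c(C)c1` gives 960 nM, two values within the scatter of each other, as a 1.5-fold higher number from compound 1 to compound 3 (0.19 log units; within the scatter) shows. Compound 2 `CCn1c(C(=O)NCCN(C)C)ccc1C(CC)(CC)c1ccc(OCC(=O)C(C)(C)C)c(C)c1` gives 2300 nM, and it stands apart from both, with a 3.7-fold higher number from compound 1 to compound 2 (0.57 log units; beyond the scatter) and a 2.4-fold lower number from compound 2 to compound 3 (0.38 log units; beyond the scatter). Compound 1 therefore sits at the low end of the numbers, alongside compound 3.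

Compound 4 `CCN(CC)CCNC(=O)c1ccc(C(CC)(CC)c2ccc(OCC(O)C(C)(C)C)c(C)c2)n1CC` differs from compound 1 elsewhere: 1-hydroxy-2,2-dimethylpropyl in place of (tert-butyl)carbonyl on a saturated chain carbon bound to an oxygen on an aromatic ring. In words, this places 1-hydroxy-2,2-dimethylpropyl in place of (tert-butyl)carbonyl on a saturated chain carbon bound to an oxygen on an aromatic ring. Going by the values given here, no measured step touches this place, since all three change only the amino group on the chain attached to the amide-type nitrogen. Among the compounds with values here, they show only that steps in this small set have been modest, such as a 3.7-fold higher number from compound 1 to compound 2 (0.57 log units; beyond the scatter). With no direction given by the data, the expected change is small, a 1.3-fold higher number from compound 1 to compound 4 (0.11 log units; within the scatter), and is not expected to exceed the scatter. For compound 4 the estimated value is 800 nM, with an expected range from 280 nM to 2200 nM.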

Compound 4, half-maximal inhibitory concentration: 490 nM
Compound 4: middle estimate off by 1.6-fold (0.21 log units), on the high side; the measured number falls inside the stated range.
By their numbers in this assay, from the lowest: compounds 4, 1 and 3 (each within the scatter of the next); then compound 2.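

For the compounds shown here, this is the first measured change at this place, on a saturated chain carbon bound to an oxygen on an aromatic ring. Putting 1-hydroxy-2,2-dimethylpropyl in place of (tert-butyl)carbonyl in this assay gives a 1.3-fold lower number from compound 1 to compound 4 (0.10 log units; within the scatter), so this swap, which removes the double bond outside the aromatic rings and adds a hydrogen-bond donor, leaves the two compounds indistinguishable in this assay. No measurement offers an explanation for this result.

As far as these compounds go, it remains open how an amine, a carboxylic acid or a longer chain at this place would read in this assay, since only these two groups can be compared here. From the compounds shown here alone, it is also open whether the same swap would read alike on compound 2 or compound 3, which carry different amino groups from compound 1.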